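The source may report more compounds than this note shows. Statements on the series, on what has been measured and on what is new or still open speak of the compounds shown alone.

Measured so far:
- Compound 1, `CCOC(=O)C1=C(C)N=C(C)/C(=C(/O)OCC)C1c1c(C)noc1CC`: 52 nM
- Compound 2, `CCOC(=O)C1=C(C)N=C(C)/C(=C(/O)OCC)C1c1c(-c2ccccc2)noc1C(C)C`: 417 nM

In an assay on membranes from heart (Cavia porcellus) for binding affinity to Voltage-dependent L-type calcium channel subunit alpha-1C (Homo sapiens) (on this read-out higher numbers stand for weaker inhibition and lower numbers for stronger inhibition), compound 2 gives the higher of the two numbers; compound 1 sits well below it, and the gap between the two lies beyond the scatter. The two structures differ in two places at once, so the gap cannot be attributed to either one.

Compound 3, `CCOC(=O)C1=C(C)N=C(C)/C(=C(/O)OCC)C1c1c(-c2ccccc2)noc1C`, keeps the phenyl group of compound 2 and changes only the other substituent on the five-membered ring: methyl in place of isopropyl on an aromatic carbon. Among the compounds with values here, no pair of measured compounds differs in this place alone, so there is no step to lean on. Within the data shown here, the only guide is that compound 1, which carries the smaller groups on this ring, gives the lower number; on that basis a modest move downward is expected for compound 3, with a 1.7-fold lower number from compound 2 to compound 3 (0.22 log units; within the scatter), though a step within the scatter is also plausible. In this assay compound 3 is estimated at 250 nM, within 80 nM to 900 nM.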

Compound 3, inhibition constant: 13.9 nM
For compound 3 the middle estimate is 18-fold (1.25 log units) above the measured one; the measured number lies below the stated range.
By their numbers in this assay, from the lowest: compound 3; then compound 1; then compound 2.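

With the phenyl group held in place, methyl in place of isopropyl on the aromatic carbon next to the ring oxygen gives a 30-fold lower number from compound 2 to compound 3 (1.48 log units; beyond the scatter) in this assay, so this position alone can move the number by a large margin. The phenyl group is also compatible with a low number at this position, as compound 3 gives 13.9 nM. Nothing at hand bears on why the step is this large.

Still open, as far as these compounds go, is how a hydrogen, an amine or a carboxylic acid would read at this position with the phenyl group kept. The separate contribution of the phenyl group also remains open, as no pair shown differs in that place alone.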